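Losing a Methyl on an Inactive Dinitrophenyl Hydrazone

The source may hold more compounds than are shown below. What is called first, only, known or untested is meant among the compounds shown, and "the series" means these compounds.

The study compares two imine-linked compounds and one hydrazone in a functional assay, read by spectrophotometry, with a stated time of 5 min; a higher number here means a weaker inhibitor, a lower number a stronger inhibitor. Compound 1 `Cc1ccc2[nH]c(=O)c(/C=N/c3ccc(C(=O)O)cc3)cc2c1` carries a methyl on the shared core and a carboxylic acid on its aryl group; in this assay compound 1 gives 409000 nM. Compound 2 `O=c1[nH]c2ccccc2cc1/C=N/c1ccccc1O` has no methyl and bears a hydroxyl on its aryl group; in this assay compound 2 gives 237000 nM. Compound 3 `Cc1ccc2[nH]c(=O)c(/C=N/Nc3ccc([N+](=O)[O-])cc3[N+](=O)[O-])cc2c1`, the hydrazone bearing two nitro groups, was reported in this assay as "not active" (no number reported), with no number attached, so it cannot be placed against the two measured values other than as, at best, a very weak inhibitor. Compound 4 `O=c1[nH]c2ccccc2cc1/C=N/Nc1ccc([N+](=O)[O-])cc1[N+](=O)[O-]` has not yet been measured. It differs from compound 3 by hydrogen in place of methyl on an aromatic carbon. Among the compounds with values here, no measured pair isolates this change, so its size is unknown; compound 1 and compound 2 differ in more than this and their values lie close together. A step no larger than the usual scatter, in either direction, is expected. Compound 4 is expected to give about 400000 nM in this assay, within 150000 nM to 1500000 nM, with a real chance that again only a limit is reported.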

Compound 4, half-maximal inhibitory concentration: "not active" (no number reported)
Compound 4 has no reported number here, and the estimate cannot be compared.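

In this assay compound 3 and compound 4 were both reported as not active without a number, so no step can be read between them. As far as these compounds go, the size of the change from methyl to hydrogen on the shared core remains open. No independent evidence bears on this result.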